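This account rests on a few compounds, and the source may have more. Where it says the series, first, only, none or still open, it means among the compounds named here.

Measured compounds in an in vitro functional assay on cells for agonist activity at Bombesin receptor subtype-3 (Homo sapiens), read by luminescence and calcium flux; on this read-out higher numbers stand for an effect only at larger amounts of compound and lower numbers for an effect already at smaller amounts:
- compound 1, `CCCCc1cnc(C(CCC)Cc2ccc(-c3ccccc3C(=O)O)cc2)[nH]1`, gives 1180 nM
- compound 2, `COc1ccc(Cc2cnc(CCc3ccc(-c4ccccc4C(=O)O)cc3)[nH]2)cc1`, gives 5360 nM
- compound 3, `CCCCc1cnc(C(Cc2ccc(-c3ccccc3C(=O)O)cc2)C(C)C)[nH]1`, gives 4620 nM

Among these three numbers compound 2 has the highest. Its nearest neighbour is compound 3, whose number lies within the scatter of that of compound 2, so the two cannot be ordered; compound 1 sits furthest away, with a number lower than that of compound 2 by a margin beyond the scatter.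

Compound 4, `O=C(O)c1ccccc1-c1ccc(CCc2ncc(-c3ccccc3)[nH]2)cc1`, has not yet been measured. It differs from compound 2 in one place: phenyl in place of 4-methoxybenzyl on an aromatic carbon.

Within the data shown here, the only measured step between neighbouring compounds, a 3.9-fold higher number from compound 1 to compound 3 (0.59 log units; beyond the scatter), concerns a different part of the molecule, the saturated chain carbon, so no measured step speaks directly to the change from compound 2 to compound 4. The expectation therefore rests on compound 2 alone, with a wide range. Compound 4 is expected to give about 4000 nM in this assay, between 1300 nM and 12000 nM. This estimate amounts to an expected 1.3-fold lower number from compound 2 to compound 4 (0.13 log units; within the scatter), which stays within the scatter.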

Compound 4, half-maximal effective concentration: 4950 nM
The estimate for compound 4 lay 1.2-fold (0.09 log units) below the measured number, within the range that was stated.
By their numbers in this assay, from the lowest: compound 1; then compounds 3, 4 and 2 (each within the scatter of the next).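

In this assay, the change at this aromatic carbon of the five-membered ring is a 1.1-fold lower number from compound 2 to compound 4 (0.03 log units; within the scatter) and so leaves the two compounds impossible to order. The group that leaves has 9 heavy atoms and 1 hydrogen-bond acceptor, while the group that enters has 6 heavy atoms and 0 hydrogen-bond acceptors, so for this pair that difference in size and oxygen content comes with no change that can be read from the numbers. No supporting measurement offers an explanation for this result.

A plain benzyl group at this position could show whether the methoxy and the extra carbon link each matter on their own. On these data alone, both compounds carry a six-membered aromatic ring of carbon only here, so the effect of an amine or a pyridine ring at this carbon remains open.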